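Swapping benzyl for phenyl on a thiosemicarbazone nitrogen

The source may hold more compounds than are shown below. What is called first, only, known or untested is meant among the compounds shown, and "the series" means these compounds.

Measured compounds:
compound 1, `CN(C)C(=S)N/N=C/c1ccc2cccnc2n1`, 970 nM in a functional assay on HeLa cells (Homo sapiens) for antiproliferative activity, read by sulforhodamine B assay, with a stated time of 72 h; a lower number here means a stronger inhibitor, a higher number a weaker inhibitor;
compound 2, `S=C(NCc1ccccc1)N/N=C/c1ccc2ccccc2n1`, 62800 nM;
compound 3, `NC(=S)N/N=C/c1ccc2cccnc2n1`, a limit of the assay, > 100000 nM.

Compound 2 gives the highest number among the two compounds with a number in this assay; its nearest neighbour is compound 1, which sits far lower. Compound 4, `S=C(N/N=C/c1ccc2ccccc2n1)Nc1ccccc1`, shares its core with compound 2 and differs in one place: phenyl in place of benzyl on an amide-type nitrogen. Going by the values given here, no measured step covers this exact change. Among the compounds with values here, the only measured step, an at least 100-fold higher number from compound 1 to compound 3 (2.01 log units; beyond the scatter), shows that what sits on the nitrogen attached to the thiocarbonyl carbon can shift the number strongly, and that one of the three values is a limit, (the limit of > 100000 nM in this assay, at which 1 of the 3 values shown sits). That step concerns a different core and a different pair of groups, so it gives direction only loosely. For compound 4 a change close to the scatter is expected, a 1.6-fold lower number from compound 2 to compound 4 (0.20 log units; within the scatter), and the estimate is 40000 nM, between 8000 nM and 150000 nM.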

Compound 4, half-maximal inhibitory concentration: 27400 nM
For compound 4 the middle estimate is 1.5-fold (0.16 log units) above the measured one, within the range that was stated.
By their numbers in this assay, from the lowest: compound 1; then compound 4; then compound 2. At a limit, above all of these: compound 3.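

In this assay, the group on the amide-type nitrogen now has a measured effect on this shared core, and the exchange is a small one in structure: benzyl has 7 heavy atoms, phenyl has 6, and both carry the same aromatic ring. Even so, the number moves, with a 2.3-fold lower number from compound 2 to compound 4 (0.36 log units; beyond the scatter), so the step is modest but not lost in the scatter. The only earlier step involved different groups on a different core, whereas this one isolates a single exchange on the core of compound 2, and nothing shown here explains its size.

The compounds shown leave open how a phenylethyl group, or a longer chain ending in an amine, would read on this same nitrogen. They also leave open whether swapping benzyl for phenyl would move the number in the same direction on the core of compound 1.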